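Changing the pyridine side group of compound 3

The source may report more compounds than this note shows. Statements on the series, on what has been measured and on what is new or still open speak of the compounds shown alone.

In an ADME assay on BE(2)-C cells (Homo sapiens) for cytotoxicity, read by MTT assay, with a stated time of 20 h (on this read-out higher numbers stand for lower toxicity in this test and lower numbers for higher toxicity in this test), compound 3 (`O=C(NCCCc1ccncc1)C1CCN(C(=O)c2cc3ccccc3n2Cc2ccc(Cl)cc2)CC1`) gives 71500 nM. Compound 2 (`C[C@@H](NC(=O)C1CCN(C(=O)c2cc3ccccc3n2Cc2ccc(Cl)cc2)CC1)c1ccncc1`) gives 92300 nM, within the scatter of compound 3. Compound 1 (`O=C(NCc1ccncc1)C1CCN(C(=O)c2cc3ccccc3n2Cc2ccc(Cl)cc2)CC1`) reaches only a limit of the assay, > 100000 nM.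

Compound 4 (`O=C(NCC1COc2cnccc21)C1CCN(C(=O)c2cc3ccccc3n2Cc2ccc(Cl)cc2)CC1`) differs from compound 3 in one group: a group of 9 heavy atoms (7 carbon, 1 nitrogen, 1 oxygen; one five-membered non-aromatic ring with 1 hetero atom, one six-membered aromatic ring with 1 hetero atom) in place of a group of 8 heavy atoms (7 carbon, 1 nitrogen; one six-membered aromatic ring with 1 hetero atom), on a saturated chain carbon bound to an amide-type nitrogen. The measured changes to this part of the molecule are all small: an at least 1.0-fold lower number from compound 1 to compound 2 (0.03 log units; that floor lies within the scatter), an at least 1.3-fold lower number from compound 1 to compound 3 (0.14 log units; that floor lies within the scatter) and a 1.3-fold lower number from compound 2 to compound 3 (0.11 log units; within the scatter), each within the scatter. Starting from compound 3 at 71500 nM, no step beyond the scatter is therefore expected in this assay. The expected change is a 1.0-fold higher number from compound 3 to compound 4 (0.02 log units; within the scatter). The estimated value for compound 4 is 75000 nM, with a range of 35000 nM to 100000 nM.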

Compound 4, half-maximal cytotoxic concentration: 75800 nM
Compound 4: middle estimate off by 1.0-fold (0.00 log units), on the low side, and the stated range covers the measured number.
By their numbers in this assay, from the lowest: compounds 3, 4 and 2 (each within the scatter of the next). At a limit, above all of these: compound 1.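

In this assay, bringing in a group with a five-membered non-aromatic ring and an oxygen at this place leaves the number within the scatter, so a larger change than a methyl or a longer chain also has no clear effect here: a 1.1-fold higher number from compound 3 to compound 4 (0.03 log units; within the scatter) and a 1.2-fold lower number from compound 2 to compound 4 (0.09 log units; within the scatter). The step to compound 1 gives only a floor: an at least 1.3-fold lower number from compound 1 to compound 4 (0.12 log units; that floor lies within the scatter). Compound 1 stands at a limit of the assay: the limit of > 100000 nM in this assay, at which 1 of the 4 values shown sits.

As far as these compounds go, whether an amine or a carboxylic acid at this place would move the number beyond the scatter stays open. From the compounds shown here alone, all four compounds keep the chlorine of the shared core, so the effect of a methoxy there is also open.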